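This account rests on a few compounds, and the source may have more. Where it says the series, first, only, none or still open, it means among the compounds named here.

Compound 1, `N#Cc1cccc(N/C(=N\O)c2nonc2SCCNC(=O)CS(N)(=O)=O)c1`, gives 44 nM in an assay for inhibition of Indoleamine 2,3-dioxygenase 1 (Homo sapiens), read by fluorescence, with a stated time of 24 h; on this read-out lower numbers stand for stronger inhibition and higher numbers for weaker inhibition.
Compound 2, `CS(=O)(=O)CC(=O)NCCSc1nonc1/C(=N/O)Nc1ccc(F)c(C(F)F)c1`, gives 14 nM in this assay.
Compound 3, `NS(=O)(=O)NCCOc1nonc1/C(=N/O)Nc1ccc(F)c(Br)c1`, gives 12 nM in this assay.

Among these three numbers compound 2 stands second highest. Compound 3 lies nearest to it, within the scatter, so no order between the two can be read. Compound 1 lies furthest, with a higher number beyond the scatter. Compound 4, `N#CCC(=O)NCCSc1nonc1/C(=N/O)Nc1ccc(F)c(C(F)F)c1`, has not been measured; it differs from compound 2 by cyano in place of methylsulfonyl on a saturated chain carbon bound to a carbonyl carbon. Within the data shown here, no measured pair shows this change, so the step is estimated without precedent. A modest step toward a higher number is expected, as a 1.8-fold higher number from compound 2 to compound 4 (0.25 log units; within the scatter), which may still fall within the scatter. Compound 4 is therefore estimated at 25 nM, with a range from 8 nM to 80 nM.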

Compound 4, half-maximal inhibitory concentration: 6.5 nM
Estimate against measurement, compound 4: 3.8-fold (0.59 log units) above; the measured number lies below the stated range.
By their numbers in this assay, from the lowest: compounds 4, 3 and 2 (each within the scatter of the next, the first and the last beyond it); then compound 1.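

On a saturated chain carbon bound to a carbonyl carbon, cyano in place of methylsulfonyl gives a 2.2-fold lower number from compound 2 to compound 4 (0.33 log units; beyond the scatter) in this assay, a modest step beyond the scatter. Among these compounds, this is the first pair differing in one place, and it shows that methylsulfonyl is not required at this position for a low number. No measured evidence here accounts for the step. Going by these compounds, how a carboxylic acid or an amine would read at this position remains open. So does whether the same change would give a similar step on the other side chains shown.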